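A few compounds are considered here, and "the series" means these few. Any claim that something is new, unique, unknown or untested is made for them only; others in the source may bear on it.

Of the compounds shown here, two that share one core have been measured in a functional assay on HL-60 cells (Homo sapiens) for inhibition, read by sulforhodamine B assay, with a stated time of 48 h, tested at 10 uM; on this read-out lower numbers stand for less inhibition and higher numbers for more inhibition at the one concentration tested (going by the name of the read-out). Compound 1 `c1cn2cc(-c3ccsc3)nc(-c3ccc4ncn(C5CCCCC5)c4c3)c2n1` gives 18.5% in this assay, and compound 2 `Clc1ccc(-c2cn3ccnc3c(-c3ccc4ncn(C5CCCCC5)c4c3)n2)cc1` gives 15.6%. Among the compounds with values here, the only step between them, a number 2.9 percentage points lower from compound 1 to compound 2 (within the scatter), lies within the scatter, so the two numbers cannot be told apart. Within the data shown here, on the numbers so far compound 2 stands at the lowest of the two, with compound 1 nearest and within the scatter of it.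

Compound 3 `Fc1ccccc1-c1cn2ccnc2c(-c2ccc3ncn(C4CCCCC4)c3c2)n1` has not yet been measured. Relative to compound 2 it shows this change: 2-fluorophenyl in place of 4-chlorophenyl on an aromatic carbon. The 4-chlorophenyl leaves and a 2-fluorophenyl enters, on an aromatic carbon. Among the measured compounds shown here, no measured step swaps one such ring for another; the one step available, a number 2.9 percentage points lower from compound 1 to compound 2 (within the scatter), changed the group at this carbon and stayed within the scatter. The expectation is therefore a step of a number 0.4 percentage points higher from compound 2 to compound 3 (within the scatter) in this assay, that is, none beyond the scatter. Compound 3 is estimated to give 16% in this assay, with a range from 4% to 30%.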

Compound 3, a percentage reported as inhibition, at one concentration (the size of the read-out at that concentration, not a potency): 9.3%
For compound 3 the middle estimate is 6.7 percentage points above the measured one; the range from low to high includes it.
By their numbers in this assay, from the lowest: compounds 3, 2 and 1 (each within the scatter of the next).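

In this assay, putting a 2-fluorophenyl in place of the 4-chlorophenyl on this aromatic carbon gives a number 6.3 percentage points lower from compound 2 to compound 3 (within the scatter), and putting it in place of the thiophen-3-yl gives a number 9.2 percentage points lower from compound 1 to compound 3 (within the scatter). Within the data shown here, the first measured swap of one phenyl ring for another thus joins the earlier ring change in staying within the scatter, so none of the three aromatic rings tried at this carbon can be told apart from the others at the one concentration tested, although the 2-fluorophenyl and the 4-chlorophenyl differ both in their halogen and in where it sits on the ring. No independent measurement bears on why the numbers fall as they do.

The 2-fluorophenyl and 4-chlorophenyl comparison cannot show whether the halogen or its place on the ring matters more, as a 4-fluorophenyl or a 2-chlorophenyl would be needed to separate the two. On these data alone, it also remains open whether a group of another kind at this carbon, such as an amine, a carboxylic acid or a longer chain, would move the number beyond the scatter, and what a change elsewhere on the shared core would do.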